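This account rests on a few compounds, and the source may have more. Where it says the series, first, only, none or still open, it means among the compounds named here.

Notes on the series. In a functional assay on HepG2 cells (Homo sapiens) for antiproliferative activity, read by MTT assay (on this read-out lower numbers stand for stronger inhibition and higher numbers for weaker inhibition), compound 1 `Cc1ccccc1NC(=O)Nc1cccc(CNc2ncnc3ccccc23)c1` gives > 50000 nM, which is a limit and not a number. Compound 2 `Cc1cccc(NC(=O)Nc2cccc(CNc3ncnc4ccccc34)c2)c1` gives > 50000 nM, again a limit. Among the compounds with values here, compound 3 `COc1ccccc1NC(=O)Nc1cccc(CNc2ncnc3ccccc23)c1` is the only one with a measured number, 17500 nM.

The change under review leads to compound 4 `COc1ccc(NC(=O)Nc2cccc(CNc3ncnc4ccccc34)c2)cc1`: 4-methoxyphenyl in place of 2-methylphenyl on an amide-type nitrogen. The methyl group is thus replaced by a methoxy group, as in compound 3, but on a 4-methoxyphenyl rather than a 2-methoxyphenyl.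

Within the data shown here, the closest precedent is an at least 2.8-fold lower number from compound 1 to compound 3 (0.45 log units; beyond the scatter). The step of an at least 2.8-fold lower number from compound 2 to compound 3 (0.45 log units; beyond the scatter) points the same way. The step that the two limits leave unreadable from compound 1 to compound 2 gives no size to work with. Among the measured compounds shown here, no measured compound yet carries the 4-methoxyphenyl group, so the precedent is a single compound and another limit remains possible.

A modest move to a lower number is therefore expected in this assay, resting on an at least 2.8-fold lower number from compound 1 to compound 3 (0.45 log units; beyond the scatter). The estimated step is an at least 1.7-fold lower number from compound 1 to compound 4 (0.25 log units; that floor lies within the scatter). The expected value for compound 4 is 28000 nM, with an estimated range of 10000 nM to 50000 nM.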

Compound 4, half-maximal inhibitory concentration: > 50000 nM
Compound 4 was reported as a limit (the forecaster's own chance of this, stated with the estimate: 40%); middle value at least 1.7-fold (0.25 log units) from the limit.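

In this assay, the methoxy group does not give the same result on the 4-methoxyphenyl group as on the 2-methoxyphenyl group, with an at least 2.8-fold higher number from compound 3 to compound 4 (0.45 log units; beyond the scatter). On the amide-type nitrogen, a methoxy group alone is therefore not enough for a measured number, and among the four aryl groups shown only the 2-methoxyphenyl group of compound 3 gives one. The steps from compound 1 and from compound 2 to compound 4 cannot be read, because each of the three compounds is reported only as the same limit: the limit of > 50000 nM in this assay, at which 3 of the 4 values shown sit.

Going by these compounds, how far compound 1, compound 2 and compound 4 lie beyond that limit remains open. Also open, on these data alone, is whether a 3-methoxyphenyl, 2-ethoxyphenyl or 2-hydroxyphenyl group on the same nitrogen would match, improve on or lose the activity of compound 3 at 17500 nM.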